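A few compounds are considered here, and "the series" means these few. Any claim that something is new, unique, unknown or untested is made for them only; others in the source may bear on it.

Working notes on the amine substituent of the series, as read in a functional assay on HeLa cells (Homo sapiens) for inhibition, read by sulforhodamine B assay; on this read-out higher numbers stand for weaker inhibition and lower numbers for stronger inhibition. Compound 2 `O=C1C=C(N2CCC2)C(=O)c2c1nc1n2[C@H]2OC[C@@H](O)[C@H]2OC1` stands at the limit of > 16000 nM in this assay, at which 1 of the 3 values shown sits, and its > 16000 nM is a limit of the assay and not a number. Compound 1 `O=C1C=C(NCc2ccccc2)C(=O)c2c1nc1n2[C@H]2OC[C@@H](O)[C@H]2OC1` gives > 8000 nM, which is also a limit. Among the measured compounds shown here, compound 3 `Cc1ccc(NC2=CC(=O)c3c(nc4n3[C@H]3OC[C@@H](O)[C@H]3OC4)C2=O)cc1` gives 6590 nM, the only true number so far in this assay.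

Compound 4 `O=C1C=C(NC2CCCCC2)C(=O)c2c1nc1n2[C@H]2OC[C@@H](O)[C@H]2OC1` carries cyclohexylamino in place of azetidin-1-yl on a double-bonded ring carbon of the shared core: cyclohexylamino in place of azetidin-1-yl on a double-bonded ring carbon.

For the measured compounds named here, the only measured step that bears on this change is a step that the two limits leave unreadable from compound 1 to compound 2, and it supplies no size to carry over. The guide is therefore indirect. Compound 4 has an amino group with a single ring substituent, as do compound 1 and compound 3, so the expectation leans on compound 3 at 6590 nM. The limit of compound 1 at > 8000 nM gives no further number to work from.

A move toward stronger inhibition is expected, with the estimated step being an at least 2.2-fold lower number from compound 2 to compound 4 (0.35 log units; beyond the scatter), although the reading may again prove to be only a limit. The estimate for compound 4 is 7000 nM, with an expected range of 2500 nM to 16000 nM.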

Compound 4, half-maximal inhibitory concentration: > 16000 nM
Compound 4 was reported as a limit; the forecaster's own chance of this, stated with the estimate: 40%; middle value at least 2.2-fold (0.35 log units) away from the limit.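

In this assay compound 4 gives > 16000 nM, a limit of the assay and not a number. No step can be read from compound 4 to either compound 1 or compound 2. The compounds shown leave open how strongly compound 1, compound 2 and compound 4 inhibit, and how each truly compares with compound 3 at 6590 nM.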